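A few compounds are considered here, and "the series" means these few. Any claim that something is new, unique, unknown or untested is made for them only; others in the source may bear on it.

Measured so far in a functional assay on L1210 cells (Mus musculus) for inhibition, with a stated time of 3 h; a lower number here means that less compound is needed, a higher number that more compound is needed for the effect:
- compound 1, `CCCCCCCCCCCC(=O)NCC(=O)N[C@@H]1[C@@H](O)[C@H](O)[C@@H](Nc2ncnc3[nH]cnc23)O[C@H]1C`: 18 uM
- compound 2, `CCOCCC(=O)NCC(=O)N[C@@H]1[C@@H](O)[C@H](O)[C@@H](Nc2ncnc3[nH]cnc23)O[C@H]1CO`: > 1000 uM
- compound 3, `CCCCCCCCCCCCCCCC(=O)NCC(=O)N[C@@H]1[C@@H](O)[C@H](O)[C@@H](Nc2ncnc3[nH]cnc23)O[C@H]1CO`: 1.6 uM

Compound 3 stands at the lowest number of the two numbers recorded in this assay; the nearest is compound 1, whose gap lies beyond the usual scatter. For compound 2 the result in this assay is a limit and not a number, > 1000 uM, and one of the three results recorded here sits at that limit (the limit of > 1000 uM in this assay, at which 1 of the 3 values shown sits).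

Compound 4, `CCCCCCCCCCCC(=O)NCC(=O)N[C@@H]1[C@@H](O)[C@H](O)[C@@H](Nc2ncnc3[nH]cnc23)O[C@H]1CO`, has not yet been measured in this assay. Its structure differs from compound 3 in one place: hydrogen in place of butyl on a saturated chain carbon, ten or more bonds along the chain from a carbonyl carbon. The saturated chain is thereby shorter by butyl, while the rest of the shared core is unchanged.

Because compound 1, which carries the same shorter chain on a core that differs in one further place, gives 18 uM, the step from compound 3 to compound 4 is expected to raise the number beyond the scatter, by roughly a 13-fold higher number from compound 3 to compound 4 (1.10 log units; beyond the scatter). Compound 4 is therefore estimated to give about 20 uM in this assay, within a range from 6 uM to 60 uM.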

Compound 4, concentration for half-maximal effect: 5.5 uM
Compound 4: middle estimate off by 3.6-fold (0.56 log units), on the high side; the measured number lies below the stated range.
By their numbers in this assay, from the lowest: compound 3; then compound 4; then compound 1. At a limit, above all of these: compound 2.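

Hydrogen in place of butyl on the saturated chain gives a 3.4-fold higher number from compound 3 to compound 4 (0.54 log units; beyond the scatter) in this assay; this is the first direct reading of chain length with the rest of the shared core unchanged, and the step is modest. With the chain held the same, hydroxy in place of hydrogen on a saturated chain carbon bound to a saturated ring carbon gives a 3.3-fold lower number from compound 1 to compound 4 (0.51 log units; beyond the scatter), so this second place also moves the number. Nonyl in place of ethoxy, two bonds along the chain from a carbonyl carbon, gives an at least 180-fold lower number from compound 2 to compound 4 (2.25 log units; beyond the scatter), a large step read against a limit of the assay and not a number.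

From the compounds shown here alone, whether a longer chain than that of compound 3 would lower the number further remains open. So does the effect of an amine or a carboxylic acid in place of hydroxy on that saturated chain carbon.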